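From Sulfanyl to Sulfonyl on a Shared Core

This account rests on a few compounds, and the source may have more. Where it says the series, first, only, none or still open, it means among the compounds named here.

Measured in a functional assay on DU-145 cells (Homo sapiens) for inhibition, read by trypan blue exclusion, with a stated time of 96 h (a higher number here means a weaker inhibitor of growth, a lower number a stronger inhibitor of growth), so far:
Compound 1 `O=C(O)c1ccc(C(=O)/C(=C\c2ccc(Cl)c([N+](=O)[O-])c2)SCc2ccc(C(F)(F)F)cc2)cc1` gives 1000 nM
Compound 2 `O=C(O)c1ccc(C(=O)/C(=C\c2ccc(Cl)c([N+](=O)[O-])c2)SCc2ccc(F)cc2)cc1` gives 1000 nM
Compound 3 `CN(C)c1ccc(/C=C(/SCc2ccc(F)cc2)C(=O)c2ccc(C(=O)O)cc2)cc1` gives 10000 nM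

Compound 2 stands level with compound 1, and both are stronger inhibitors of growth than compound 3. Compound 4 `O=C(O)c1ccc(C(=O)/C(=C\c2ccc(Cl)c([N+](=O)[O-])c2)S(=O)(=O)Cc2ccc(Br)cc2)cc1` differs from compound 2 by a single swap ((4-bromobenzyl)sulfonyl in place of (4-fluorobenzyl)sulfanyl on a double-bonded chain carbon bound to a carbonyl carbon and a double-bonded chain carbon).

The closest evidence is no change at the digits printed from compound 1 to compound 2 (within the scatter) for fluoro in place of trifluoromethyl on an aromatic carbon, which hints that exchanging such groups may matter little. The larger step of a 10-fold higher number from compound 2 to compound 3 (1.00 log units; beyond the scatter) came with 4-(dimethylamino)phenyl in place of 4-chloro-3-nitrophenyl, and compound 4 keeps the latter, so that step says little here. Among the measured compounds shown here, no measured step covers the change from sulfanyl to sulfonyl, which leaves real uncertainty.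

In this assay the expected change is none beyond the scatter, and no change at the digits printed from compound 2 to compound 4 (within the scatter) is the estimated step, with no direction favoured. The estimated value of compound 4 is 1000 nM within an expected range of 200 nM to 5000 nM for now.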

Compound 4, concentration for 50% growth inhibition: 25000 nM
Beside the measured number, compound 4's estimate is 25-fold (1.40 log units) below it; the whole stated range lies below it.
By their numbers in this assay, from the lowest: compounds 1 and 2 (each within the scatter of the next); then compound 3; then compound 4.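

In this assay the place on the double-bonded chain carbon bound to a carbonyl carbon and a double-bonded chain carbon proves sensitive: (4-bromobenzyl)sulfonyl in place of (4-fluorobenzyl)sulfanyl gives a 25-fold higher number from compound 2 to compound 4 (1.40 log units; beyond the scatter) and so a much weaker inhibitor of growth. Among the compounds shown here, earlier, fluoro in place of trifluoromethyl gave no change at the digits printed from compound 1 to compound 2 (within the scatter) and showed only that one exchange on the ring of this group left the number unmoved, whereas this larger swap does not. Nothing measured here explains the loss.

Sulfonyl and bromo enter together in this one step, and the compounds shown cannot say which of them goes with the higher number. A (4-fluorobenzyl)sulfonyl or a (4-bromobenzyl)sulfanyl group at this place would separate the two.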